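Ethyl ester of an inactive acid in phosphodiesterase 1 assay

This account rests on a few compounds, and the source may have more. Where it says the series, first, only, none or still open, it means among the compounds named here.

Compound 2 `COc1ccc(C2CNC(=O)C2)cc1OCCCC(=O)O` is the acid of this pair. In an assay on isolated protein for inhibition of phosphodiesterase 1 (Bos taurus), read by cGMP accumulation, in the presence of a further agent that is not named here (a higher number here means a weaker inhibitor, a lower number a stronger inhibitor), compound 2 gives > 1000000 nM, which is a limit of the assay and not a number. Compound 1 `C=C(C)COc1cc(C2CNC(=O)C2)ccc1OC` likewise gives > 1000000 nM in this assay, again a limit. The step that the two limits leave unreadable from compound 1 to compound 2 therefore cannot be read, since the limit of > 1000000 nM in this assay, at which 2 of the 2 values shown sit, describes every value shown. Compound 3 `CCOC(=O)CCCOc1cc(C2CNC(=O)C2)ccc1OC` differs from compound 2 by ethyl in place of hydrogen on an oxygen next to a carbonyl group, so the acid becomes its ethyl ester. Among the measured compounds shown here, no measured step bears on this change, and the two limits give no direction to expect. Compound 3 is expected to stay where compound 2 stands, which is the limit > 1000000 nM, so the step of a number no higher from compound 2 to compound 3 (the limit leaves the size open) is estimated as none beyond the scatter. Compound 3 is thus estimated at 1000000 nM in this assay, within a range from 100000 nM to 5000000 nM.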

Compound 3, half-maximal inhibitory concentration: > 1000000 nM
Compound 3 ended at the assay's limit; the forecaster's own chance of this, stated with the estimate: 80%; the middle value lies on the limit itself.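

No step among compound 1, compound 2 and compound 3 can be read in this assay, because all three values are limits of the assay: the limit of > 1000000 nM in this assay, at which 3 of the 3 values shown sit.

The compounds shown leave open how the chain on the shared core bears on inhibition in this assay, since none gives a readable number.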